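Amino for dimethylamino on the carbonyl-bound chain carbon

A few compounds are considered here, and "the series" means these few. Any claim that something is new, unique, unknown or untested is made for them only; others in the source may bear on it.

Compound 1 `COc1ccc(C(=O)c2ccc(OC)c3c2OC(C)(C)C=C3)c(NC(=O)CN)c1` and compound 2 `COc1ccc(C(=O)c2ccc(OC)c3c2OC(C)(C)C=C3)c(NC(=O)CN(C)C)c1` share one core; compound 3 `COc1ccc(C(=O)c2cc(OC)c(OC)c(OC)c2)c(NC(=O)CN(C)C)c1` and compound 4 `COc1ccc(C(=O)c2cc(OC)c(OC)c(OC)c2)c(NC(=O)CN)c1` share another, and the difference between the two cores is not broken down here. In a functional assay on MCF7 cells (Homo sapiens) for antiproliferative activity, read by MTT assay, with a stated time of 48 h (on this read-out lower numbers stand for stronger inhibition and higher numbers for weaker inhibition), compound 1 gives 410 nM, compound 2 gives 2680 nM and compound 3 gives 790 nM. The change amino in place of dimethylamino on a saturated chain carbon bound to a carbonyl carbon gave a 6.5-fold lower number from compound 2 to compound 1 (0.82 log units; beyond the scatter). The same change, (amino in place of dimethylamino on a saturated chain carbon bound to a carbonyl carbon), with the place identical in both pairs, now runs from compound 3 to compound 4. Because a 6.5-fold lower number from compound 2 to compound 1 (0.82 log units; beyond the scatter) was seen on the core of compound 1, a step in the same direction is expected for compound 4, tempered somewhat since it rests on one precedent on another core: a 4.9-fold lower number from compound 3 to compound 4 (0.69 log units; beyond the scatter). Compound 4 is thus estimated at 160 nM, expected to fall between 55 nM and 500 nM.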

Compound 4, half-maximal inhibitory concentration: 270 nM
Compound 4: middle estimate off by 1.7-fold (0.23 log units), on the low side, and the stated range covers the measured number.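

In this assay, amino in place of dimethylamino on a saturated chain carbon bound to a carbonyl carbon gave a 2.9-fold lower number from compound 3 to compound 4 (0.47 log units; beyond the scatter), the same direction as on the core of compound 1, and the sizes of the two steps do not differ beyond the scatter: the same change on two cores in this assay, a 6.5-fold lower number (0.82 log units; beyond the scatter) from compound 2 to compound 1 and a 2.9-fold lower number (0.47 log units; beyond the scatter) from compound 3 to compound 4, 2.2-fold (0.35 log units) apart, within the scatter of two such steps. The change thus carried over between these two cores in direction, and no dependence of its size on the core can be claimed. This rests on two pairs in a single cell assay and does not show that the change would carry to any further core or read-out.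

The compounds shown leave open how methylamino, a pyrrolidine or a longer chain ending in amino would read at this place. They also leave open how a carboxylic acid would read there.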